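Urea tail variation on a shared sulfonamide core

The compounds below may be only part of what the source reports. "The series", "measured", "known", "first", "only" and "open" are said of these compounds alone.

Measured compounds:
- compound 1 `COc1ncc(-c2ccc3nc(NC(=O)NCCN4CCCC4)nn3c2)cc1NS(=O)(=O)c1ccc(F)cc1`: 960 nM
- compound 2 `COc1ncc(-c2ccc3nc(NC(=O)N4CCCC4)nn3c2)cc1NS(=O)(=O)c1ccc(F)cc1`: 3570 nM

In a functional assay on A549 cells (Homo sapiens) for cytotoxicity, read by MTT assay, with a stated time of 72 h (a lower number here means a stronger inhibitor, a higher number a weaker inhibitor), compound 1 gives 960 nM and compound 2 gives 3570 nM. Compound 1 stands with the lowest number of the two, and the single shown step, a 3.7-fold higher number from compound 1 to compound 2 (0.57 log units; beyond the scatter), separates it from compound 2 by more than the scatter.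

Compound 3 `COc1ncc(-c2ccc3nc(NC(=O)NCCN4CCN(C)CC4)nn3c2)cc1NS(=O)(=O)c1ccc(F)cc1` is not yet measured. It differs from compound 1 in one place: 4-methylpiperazin-1-yl in place of pyrrolidin-1-yl on a saturated chain carbon, two bonds along the chain from an amide-type nitrogen. The chain between the amide-type nitrogen and the terminal ring is kept; only the terminal ring is exchanged.

For the measured compounds named here, no measured step bears directly on this exchange. The step from compound 1 to compound 2 concerns removal of the (2-(pyrrolidin-1-yl)ethyl)amino chain, not a swap of the ring at its end, so it says nothing about replacing pyrrolidin-1-yl with 4-methylpiperazin-1-yl. With the chain retained, the expectation is a step of a 1.0-fold higher number from compound 1 to compound 3 (0.02 log units; within the scatter), that is, no shift beyond the scatter in either direction. Compound 3 is therefore estimated at 1000 nM in this assay, with a range of 400 nM to 2500 nM.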

Compound 3, half-maximal inhibitory concentration: 1050 nM
For compound 3 the middle estimate is 1.1-fold (0.02 log units) below the measured one; low and high end bracket the measured number.
By their numbers in this assay, from the lowest: compounds 1 and 3 (each within the scatter of the next); then compound 2.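

Working notes on the urea tail. In this assay the terminal ring on the 2-carbon chain can be exchanged without a shift beyond the scatter: 4-methylpiperazin-1-yl in place of pyrrolidin-1-yl gives a 1.1-fold higher number from compound 1 to compound 3 (0.04 log units; within the scatter) and so this position accepts a six-membered ring with 2 hetero atoms as readily as the five-membered ring with 1. The gap to the chainless urea also reappears with the new ring, as a 3.4-fold lower number from compound 2 to compound 3 (0.53 log units; beyond the scatter) shows, so the advantage of a chain-bearing tail over pyrrolidin-1-yl on the carbonyl carbon is now seen with two different terminal rings rather than one. Nothing available explains why the two terminal rings read alike or why the chain-bearing compounds stand apart from compound 2.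

The compounds shown leave open whether the ring at the chain end matters at all, since a morpholin-4-yl group or a simple dimethylamino group at that position would test the need for the second ring nitrogen or for any ring. They also leave open how the chain length itself counts, which a longer chain such as 3-(pyrrolidin-1-yl)propyl would address.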